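Compound 3 and the step from 4-methylbenzyl to benzyl

This account rests on a few compounds, and the source may have more. Where it says the series, first, only, none or still open, it means among the compounds named here.

Within the data shown here, in a functional assay on aorta (Rattus norvegicus, strain Sprague-Dawley) (a lower number here means that less compound is needed, a higher number that more compound is needed for the effect), compound 1 (`Cc1nn(-c2ccccc2)c2nc(OCc3ccccc3F)c(-c3nc(N)cc(N)n3)cc12`) gives 2200 nM as the only number so far. Compound 2 (`Cc1ccc(COc2nc3c(cc2-c2nc(N)cc(N)n2)c(C)nn3-c2ccccc2)cc1`) has no place on that scale: its result reads "not determined" (no result reported) and no single value exists for it, so it cannot be ranked against compound 1. Compound 3 (`Cc1nn(-c2ccccc2)c2nc(OCc3ccccc3)c(-c3nc(N)cc(N)n3)cc12`) remains unmeasured. The step hydrogen in place of methyl on an aromatic carbon puts hydrogen in place of methyl on an aromatic carbon, para to a large group, turning 4-methylbenzyl into benzyl. Among the measured compounds shown here, no measured pair shows what this change does. For the measured compounds named here, the sole anchor is compound 1 at 2200 nM and, in this assay, the expected step is none beyond the scatter, with no direction favoured. Compound 3 is expected at 2000 nM with an estimated range from 500 nM to 8000 nM as a working figure.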

Compound 3, half-maximal effective concentration: 10800 nM
For compound 3 the middle estimate is 5.4-fold (0.73 log units) below the measured one; the whole stated range lies below it.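

The series now holds its first readable step in this assay: a 4.9-fold higher number from compound 1 to compound 3 (0.69 log units; beyond the scatter), a change that removes the fluoro group and leaves a plain benzyl. The aromatic ring of the benzyl group is therefore a place where exchanging a single atom moves the number beyond the scatter, and the fluoro compound 1 needs less compound for the effect than the plain benzyl compound 3. Nothing available explains this step.

From the compounds shown here alone, the step from 4-methylbenzyl to benzyl cannot be read, as compound 2 has no number, so it stays open whether methyl on that ring shifts the result as fluoro does. Also open, going by these compounds, is how a methoxy group, an amine or a carboxylic acid on that ring would read, or a longer chain in place of benzyl.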